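Carbamoyl in place of isopropyl on the ester chain

This account rests on a few compounds, and the source may have more. Where it says the series, first, only, none or still open, it means among the compounds named here.

The account starts from compound 1 `CCOc1cc(NC(=O)C2(NC(=O)c3ccc4c(C5CCCC5)c(-c5ncc(Cl)cn5)n(C)c4c3)CCC2)ccc1/C=C/C(=O)OCC(C)C`. In an ADME assay (liver) for pharmacokinetics, with Liver microsome (Homo sapiens) as the target, using microsomes (a higher number here means that the compound lasts longer, a lower number that the compound disappears faster), compound 1 gives > 5 h, which is a limit of the assay and not a number. Compound 2 `CCOc1cc(NC(=O)C2(NC(=O)c3ccc4c(C5CCCC5)c(-c5ncc(Cl)cn5)n(C)c4c3)CCC2)ccc1/C=C/C(=O)OCc1ccccc1` likewise gives > 5 h, again a limit. Compound 3 `CCOc1cc(NC(=O)C2(NC(=O)c3ccc4c(C5CCCC5)c(-c5ncc(Cl)cn5)n(C)c4c3)CCC2)ccc1/C=C/C(=O)OCC(=O)OC` gives a measured number, 2.1 h. Between the first two there is a step that the two limits leave unreadable from compound 1 to compound 2. Against compound 3, however, the steps are readable: an at least 2.3-fold lower number from compound 1 to compound 3 (0.37 log units; beyond the scatter) and an at least 2.3-fold lower number from compound 2 to compound 3 (0.37 log units; beyond the scatter), both beyond the scatter. Compound 1 therefore stands at the limit of > 5 h in this assay, at which 2 of the 3 values shown sit, together with compound 2, while compound 3 stands clearly lower.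

The compound not yet measured is compound 4 `CCOc1cc(NC(=O)C2(NC(=O)c3ccc4c(C5CCCC5)c(-c5ncc(Cl)cn5)n(C)c4c3)CCC2)ccc1/C=C/C(=O)OCC(=O)N(C)C(C)C`. It differs from compound 1 as follows: isopropyl(methyl)carbamoyl in place of isopropyl on a saturated chain carbon bound to an oxygen next to a carbonyl group. The step that bears on this change most directly is the one in which a carbonyl-bearing group also enters on that same carbon, namely an at least 2.3-fold lower number from compound 1 to compound 3 (0.37 log units; beyond the scatter). Whether the isopropyl(methyl)carbamoyl group behaves like the methoxycarbonyl group of compound 3 cannot be read from these three compounds alone, and compound 2 shows that a bulkier group need not leave the limit. The expected step is an at least 1.6-fold lower number from compound 1 to compound 4 (0.22 log units; that floor lies within the scatter), a moderate drop. For compound 4 the estimate in this assay is 3 h, with a range from 1.5 h to 5.5 h.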

Compound 4, half-life: 0.65 h
For compound 4 the middle estimate is 4.6-fold (0.66 log units) above the measured one; the whole stated range lies above it.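

In this assay, putting isopropyl(methyl)carbamoyl on the saturated chain carbon bound to an oxygen next to a carbonyl group gives an at least 7.6-fold lower number from compound 1 to compound 4 (0.88 log units; beyond the scatter), and replacing the phenyl of compound 2 there gives an at least 7.6-fold lower number from compound 2 to compound 4 (0.88 log units; beyond the scatter), so this place can carry a far larger loss than the methoxycarbonyl of compound 3 had revealed. The atoms on the carbonyl carbon of the entering group also count, since isopropyl(methyl)amino in place of methoxy gives a 3.2-fold lower number from compound 3 to compound 4 (0.51 log units; beyond the scatter), a step beyond the scatter, which means that the mere presence of a carbonyl-bearing group on this carbon does not fix the result. Compound 1 and compound 2 each stand at a limit of the assay, so the step between them cannot be read and the two steps down to compound 4 give only a minimum size: the limit of > 5 h in this assay, at which 2 of the 4 values shown sit.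

The compounds shown leave open whether the lower number follows the amide carbonyl itself or the isopropyl on its nitrogen, which a dimethylcarbamoyl or an unsubstituted carbamoyl group in the same place would separate. They also leave open how a carboxylic acid or a longer chain on that carbon would read in this assay.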